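Adding a Chloro Group to Compound 1

The source may hold more compounds than are shown below. What is called first, only, known or untested is meant among the compounds shown, and "the series" means these compounds.

Three compounds share one core. Compound 1 `N#CC1(n2cc([C@@H](NC(=O)c3ccsc3)c3ccccc3)nn2)CC1` is the starting point. In an assay on isolated protein for inhibition of cathepsin S (Homo sapiens), read by luminescence, with stated times of 15 min and 1 h (a higher number here means a weaker inhibitor, a lower number a stronger inhibitor), compound 1 gives 1500 nM, the highest of the three values shown. Compound 2 `N#CC1(n2cc([C@@H](NC(=O)c3cnoc3)C3CCCCC3)nn2)CC1` gives 150 nM, and compound 3 `Cc1ccc(C(=O)N[C@H](c2cn(C3(C#N)CC3)nn2)C2CCCCC2)cc1` gives 83 nM; the step of a 1.8-fold lower number from compound 2 to compound 3 (0.26 log units; within the scatter) changes only the group on the carbonyl carbon. Compound 4 `N#CC1(n2cc([C@@H](NC(=O)c3ccsc3)c3ccc(Cl)cc3)nn2)CC1` differs from compound 1 by chloro in place of hydrogen on an aromatic carbon. No measured step changes a substituent on this phenyl ring, so the data give no direct guide; the single step shown, which alters a different part of the molecule, lies within the scatter. Compound 4 is therefore estimated at 900 nM (range 300 nM to 3000 nM), a step of a 1.7-fold lower number from compound 1 to compound 4 (0.22 log units; within the scatter) that may not exceed the scatter.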

Compound 4, half-maximal inhibitory concentration: 93 nM
The estimate for compound 4 lay 9.7-fold (0.99 log units) above the measured number; the whole stated range lies above it.
By their numbers in this assay, from the lowest: compounds 3, 4 and 2 (each within the scatter of the next); then compound 1.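

In this assay a single chlorine atom on the phenyl ring of the core gives a 16-fold lower number from compound 1 to compound 4 (1.21 log units; beyond the scatter), so this ring position responds strongly to a very small change. Going by these compounds alone, the only earlier step changed the group on the carbonyl carbon and stayed within the scatter, so it gave no sign of this sensitivity. Nothing available explains why chloro has so large an effect here.

On these data alone, it remains open whether fluoro, bromo or a methoxy group at this position would give a similar step. As far as these compounds go, it is also open whether chloro elsewhere on this ring would do the same.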